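The source may report more compounds than this note shows. Statements on the series, on what has been measured and on what is new or still open speak of the compounds shown alone.

Series notes. Compound 1 `C=CCn1/c(=N\C#N)n([C@H]2OC(CO)[C@@H](O)[C@H]2O)c2cc(N)nc(O)c21` is the high point in a functional assay on the whole organism (B cells) with Mus musculus as the target (a higher number here means a larger maximal response, a lower number a smaller maximal response), where compound 1 gives 85%. Compound 2 `Nc1nc(O)c2c(n1)n(C1OC(CO)[C@@H](O)[C@H]1O)c(=O)n2CC(O)CSc1ccccc1` stands second highest of the three numbers obtained: in this assay compound 2 gives 12%. Its nearest neighbour is compound 3 `CC1OC(n2c(=O)n(C)c3c(O)nc(N)nc32)[C@H](O)[C@@H]1O`, which in this assay gives 0%, a gap that lies beyond the scatter; the furthest is compound 1, whose number stands higher than that of compound 2 by a margin well beyond the scatter. Among the measured compounds shown here, no pair among the three differs in one place only, so no single measured step is available to calibrate the change below.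

Compound 4 `Nc1nc(O)c2c(n1)n(C1OC(CO)[C@@H](O)[C@H]1O)c(=O)n2Cc1ccccc1` is not yet measured. It differs from compound 2 as follows: phenyl in place of 1-hydroxy-2-(phenylsulfanyl)ethyl on a saturated chain carbon bound to an aromatic nitrogen. The shared core of compound 2 and compound 4 is kept; only the group on that chain carbon changes.

Nothing measured bears directly on this change. Compound 3 gives the lowest number and compound 2 a low one; both sit far from compound 1. The step from compound 2 to compound 4 is therefore expected to be small, a number 2 percentage points lower from compound 2 to compound 4 (within the scatter), with no change beyond the scatter and, if anything, a slight decrease. In this assay compound 4 is expected to give 10%, with a range from 0% to 35%.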

Compound 4, largest response reached (reported as maximal response), in percent of the reference or control that the assay uses: 110%
Compound 4: middle estimate off by 100 percentage points, on the low side; measured number above the stated range.
By their numbers in this assay, from the lowest: compound 3; then compound 2; then compound 1; then compound 4.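

On the saturated chain carbon bound to an aromatic nitrogen, the group carried there has a large effect in this assay, with a number 98 percentage points higher from compound 2 to compound 4 (beyond the scatter) when phenyl takes the place of 1-hydroxy-2-(phenylsulfanyl)ethyl. Among the compounds shown here, this is the first step that can be read at a single place, and it shows that the low maximal response of compound 2 is not fixed by the shared core, as changing this one group while keeping that core is enough to raise the number far beyond the scatter. Nothing available explains the size of this step.

The change removes the hydroxyl, the sulfur and part of the chain together, so the compounds shown cannot assign the step to any one of them, and a 2-(phenylsulfanyl)ethyl group without the hydroxyl or a plain ethyl chain ending in phenyl would be needed to separate them. As far as these compounds go, it also remains open whether the high response depends on the phenyl ring itself or would survive with a methyl group, an amine or a carboxylic acid on the same chain carbon.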